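The compounds below may be only part of what the source reports. "The series", "measured", "known", "first", "only" and "open" are said of these compounds alone.

Working notes on the series. Three compounds have numbers or outcomes in an assay on microsomes from liver for inhibition of sterol O-acyltransferase 1 (Rattus norvegicus); a lower number here means a stronger inhibitor, a higher number a weaker inhibitor. Compound 1 `CCCCCCN(CCCCCSc1nc2c[nH]cnc-2n1)C(=O)Nc1ccc(F)cc1F` gives 860 nM in this assay. Compound 2 `CCCCCCCN(CCCCCSc1nc(N)c2c[nH]nc2n1)C(=O)Nc1ccc(F)cc1F` gives 4230 nM in this assay, which is the highest of the two numbers reported; the gap down to compound 1 lies beyond the usual scatter, so compound 2 is the weaker of the two measured ones. Compound 3 `CCCCCCCN(CCCCCSc1nc(N)c2c[nH]nc2n1)C(=O)NC(C)C`, the isopropyl urea, is reported in this assay as "not active" (no number reported), with no number given. Among the measured compounds shown here, no pair of measured compounds differs in a single place, so no isolated step can be read from them.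

Compound 4 `CCCCCCCN(CCCCCSc1n[nH]c(-c2ccccc2)n1)C(=O)Nc1ccc(F)cc1F` is the next one to be run in this assay. It differs from compound 2 only at the thioether: a group of 11 heavy atoms (8 carbon, 3 nitrogen; one five-membered aromatic ring with 3 hetero atoms, one six-membered aromatic ring of carbon only) in place of a group of 10 heavy atoms (5 carbon, 5 nitrogen; one five-membered aromatic ring with 2 hetero atoms, one six-membered aromatic ring with 2 hetero atoms), on a sulfur. The same heptyl chain and the difluorophenyl urea remain.

For the measured compounds named here, no measured step tells how an exchange of this kind on the sulfur plays out here; compound 1 and compound 2, with different bicyclic groups on the sulfur, sit apart by more than the scatter, which shows that this part of the molecule can move the number. The step is expected to be modest and unclear in direction, a 1.4-fold lower number from compound 2 to compound 4 (0.15 log units; within the scatter). Compound 4 is estimated at 3000 nM, with a range from 700 nM to 13000 nM.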

Compound 4, half-maximal inhibitory concentration: 4000 nM
Beside the measured number, compound 4's estimate is 1.3-fold (0.12 log units) below it; low and high end bracket the measured number.
By their numbers in this assay, from the lowest: compound 1; then compounds 4 and 2 (each within the scatter of the next).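

In this assay, replacing the group of 10 heavy atoms on the sulfur with 5-phenyl-1H-1,2,4-triazol-3-yl gives a 1.1-fold lower number from compound 2 to compound 4 (0.02 log units; within the scatter). Among the compounds shown here, this is the first step that isolates this position, and it shows that the two groups cannot be told apart in this assay, even though they differ in ring types and the entering group has fewer hydrogen-bond donors and acceptors. No supporting measurement bears on this result, so it offers no explanation for the match between the two groups.

Compound 1 differs from compound 2 and compound 4 in both the chain on the urea nitrogen and the group on the sulfur, so the compounds shown do not reveal which of these changes accounts for its separate number. They also leave open whether an amine or a carboxylic acid on the phenyl ring of the 5-phenyl-1H-1,2,4-triazol-3-yl group, or a longer chain in place of the heptyl chain, would move the number beyond the scatter.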